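Trimming the chain on compound 3

The source may report more compounds than this note shows. Statements on the series, on what has been measured and on what is new or still open speak of the compounds shown alone.

Of the compounds shown here, three have been measured in an assay for displacement of a labelled ligand from protein arginine N-methyltransferase 1 (Homo sapiens), read by scintillation proximity assay, with stated times of 5 min and 8 min, tested at 90 uM; on this read-out lower numbers stand for a weaker effect and higher numbers for a stronger effect at the one concentration tested. Compound 1 `CN1/C(=C/C=C/C2=[N+](CCCc3ccccc3)c3ccccc3C2(C)C)C(C)(C)c2ccccc21` gives 101%, compound 2 `CC1=[N+](CCCc2ccccc2)c2ccccc2C1(C)C` gives 80%, and compound 3 `CCCC[N+]1=C(/C=C/C=C2/N(C)c3ccccc3C2(C)C)C(C)(C)c2ccccc21` gives 79%. Compound 3 stands lowest of the three numbers, within the scatter of compound 2, while the step of a number 22 percentage points lower from compound 1 to compound 3 (beyond the scatter) is a modest drop beyond the scatter.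

Compound 4 `CC[N+]1=C(/C=C/C=C2/N(C)c3ccccc3C2(C)C)C(C)(C)c2ccccc21` differs from compound 3 by hydrogen in place of ethyl on a saturated chain carbon, two bonds along the chain from a double-bonded nitrogen in a ring. Going by the values given here, the single measured step concerned a different place on the same chain, so it bears only loosely here; it suggests that shortening this chain tends to lower the read-out slightly, if at all. Compound 4 is therefore estimated at 72%, ranging from 55% to 90%, an expected step of a number 7 percentage points lower from compound 3 to compound 4 (within the scatter) that should stay within the scatter.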

Compound 4, a percentage reported as inhibition, at one concentration (the size of the read-out at that concentration, not a potency): 41%
Compound 4: middle estimate off by 31 percentage points, on the high side, outside the stated range (below it).
By their numbers in this assay, from the lowest: compound 4; then compounds 3 and 2 (each within the scatter of the next); then compound 1.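

Cutting butyl to ethyl gives a number 38 percentage points lower from compound 3 to compound 4 (beyond the scatter), so the read-out is far more sensitive to the length of this chain than the earlier compounds suggested. Removing benzyl from the same carbon gives a number 60 percentage points lower from compound 1 to compound 4 (beyond the scatter), and across compounds 1, 3 and 4 the number falls as the chain gets shorter. No available evidence bears on what lies behind this drop. Still open, on these data alone, is whether the fall is gradual or sudden, which a propyl chain would help to show, and whether an amine at the chain end could replace the phenyl.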